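The source may report more compounds than this note shows. Statements on the series, on what has been measured and on what is new or still open speak of the compounds shown alone.

Compound 1, `O=S(=O)(/C=C/c1ccccn1)c1cccc(F)c1`, is one of three compounds tested in an assay on U2OS cells for activation of nuclear factor erythroid 2-related factor 2 (Homo sapiens), read by beta-arrestin recruitment, with a stated time of 6 h; a higher number here means that more compound is needed for the effect, a lower number that less compound is needed. Compound 1 gives 1680 nM, which places it second highest among the three; compound 3, `O=S(=O)(/C=C/c1ccc(Cl)cn1)c1cccc(F)c1`, gives 2500 nM, and compound 2, `O=S(=O)(/C=C/c1ncccc1Cl)c1cccc(F)c1`, gives 84 nM. The step from compound 1 to compound 2 is a 20-fold lower number from compound 1 to compound 2 (1.30 log units; beyond the scatter), and the step from compound 1 to compound 3 is a 1.5-fold higher number from compound 1 to compound 3 (0.17 log units; within the scatter). Both of these steps put a chlorine onto the ring that holds the nitrogen, and they show that the outcome of adding chlorine depends strongly on where it sits.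

Compound 4, `O=S(=O)(/C=C/c1ccccn1)c1cccc(Cl)c1`, differs from compound 1 in another way: chloro in place of fluoro on an aromatic carbon. The change sits on the six-membered aromatic ring of carbon only, meta to a large group, so neither measured step directly covers it. Among the measured compounds shown here, no step of this exact kind has been measured, and the two known steps point in opposite directions, so the expectation for this assay is a step that stays within the scatter, with wide uncertainty. Compound 4 is therefore estimated at 1400 nM, between 450 nM and 4500 nM, which means an expected step of a 1.2-fold lower number from compound 1 to compound 4 (0.08 log units; within the scatter).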

Compound 4, half-maximal effective concentration: 1430 nM
Beside the measured number, compound 4's estimate is 1.0-fold (0.01 log units) below it; the measured number falls inside the stated range.
By their numbers in this assay, from the lowest: compound 2; then compounds 4, 1 and 3 (each within the scatter of the next).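

Putting chloro in place of fluoro on the six-membered aromatic ring of carbon only, meta to a large group, gives a 1.2-fold lower number from compound 1 to compound 4 (0.07 log units; within the scatter) in this assay. This is the first change shown on that ring, as the earlier steps all altered the ring that holds the nitrogen, and it shows that the two halogens cannot be told apart at this place in this assay. No measured evidence explains why the swap makes so little difference.

Going by these compounds, whether the swap would be just as quiet in compound 2, with its much lower number, remains open. The compounds shown also leave open what a plain hydrogen, an amine or a carboxylic acid would do at this place, since both groups compared here are halogens.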